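Moving a Methoxy Group on the Sulfonamide Nitrogen Substituent

The source may report more compounds than this note shows. Statements on the series, on what has been measured and on what is new or still open speak of the compounds shown alone.

Three compounds have been measured in a functional assay on MCF7 cells (Homo sapiens) for antiproliferative activity, read by sulforhodamine B assay, with a stated time of 48 h (on this read-out lower numbers stand for stronger inhibition and higher numbers for weaker inhibition), so far
- Compound 1 `Cc1ccc(NS(=O)(=O)c2ccc(N3CCNC3=O)cc2)cc1` gives 610 nM
- Compound 2 `Cc1ccc(NS(=O)(=O)c2ccc(N3CCNC3=O)cc2)cc1C` gives 230 nM
- Compound 3 `COc1ccccc1NS(=O)(=O)c1ccc(N2CCNC2=O)cc1` gives 770 nM

Compound 3 gives 770 nM in this assay and its place among the others is set by two steps. These are a 1.3-fold higher number from compound 1 to compound 3 (0.10 log units; within the scatter) and a 3.3-fold higher number from compound 2 to compound 3 (0.52 log units; beyond the scatter) so only compound 2 stands clearly apart from it.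

The next compound, compound 4 `COc1cccc(NS(=O)(=O)c2ccc(N3CCNC3=O)cc2)c1` has the same atoms as compound 3, joined differently. It carries 3-methoxyphenyl in place of 2-methoxyphenyl on a sulfonamide nitrogen and the rest of the molecule is unchanged.

Among the measured compounds shown here, no measured step moves a methoxy group, so the evidence is indirect. The closest guides are a 1.3-fold higher number from compound 1 to compound 3 (0.10 log units; within the scatter) and a 2.7-fold lower number from compound 1 to compound 2 (0.42 log units; beyond the scatter) which also change the group on the sulfonamide nitrogen. Such changes have so far stayed within the scatter or been modest, so no large jump is expected. The expected change is a 1.5-fold lower number from compound 3 to compound 4 (0.19 log units; within the scatter) in this assay and no step beyond the scatter is expected. Compound 4 is estimated at 500 nM with an expected range from 170 nM to 1500 nM in repeat measurements.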

Compound 4, half-maximal inhibitory concentration: 120 nM
For compound 4 the middle estimate is 4.2-fold (0.62 log units) above the measured one; measured number outside the range, below it.
By their numbers in this assay, from the lowest: compounds 4 and 2 (each within the scatter of the next); then compounds 1 and 3 (each within the scatter of the next).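

Compound 3 and compound 4 have the same atoms, yet moving from 2-methoxyphenyl to 3-methoxyphenyl on the sulfonamide nitrogen gives in this assay a 6.4-fold lower number from compound 3 to compound 4 (0.81 log units; beyond the scatter), which shows that at this position the place of the methoxy group on the phenyl ring matters and not only which atoms are present. The new group also stands clearly apart from 4-methylphenyl, with a 5.1-fold lower number from compound 1 to compound 4 (0.71 log units; beyond the scatter), while a 1.9-fold lower number from compound 2 to compound 4 (0.28 log units; within the scatter) puts it level with 3,4-dimethylphenyl, so two differently substituted rings now share the low end of this small series and 2-methoxyphenyl and 4-methylphenyl share the high end. Nothing available here explains why moving the methoxy group has this effect.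

The compounds shown leave open whether a longer chain in place of the methyl of the methoxy group, or an amine or a carboxylic acid on the phenyl ring, would keep the number as low as in compound 4. From the compounds shown here alone, the shared core also stays the same throughout, so how a change there would act on this read-out remains unknown.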